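The compounds below may be only part of what the source reports. "The series", "measured", "known", "first", "only" and "open" are said of these compounds alone.

Measured so far in a functional assay on HEK293 cells for agonist activity at D(4) dopamine receptor (Homo sapiens), read by FLIPR; on this read-out higher numbers stand for an effect only at larger amounts of compound and lower numbers for an effect already at smaller amounts:

Compound 1 `O=C(CN1CCC(c2cccc[n+]2[O-])CC1)Nc1cccc(F)c1` gives 160 nM in this assay.
Compound 2 `Cc1cc(Br)ccc1NC(=O)CN1CCC(c2cccc[n+]2[O-])CC1` gives 66 nM in this assay.
Compound 3 `O=C(CN1CCC(c2cccc[n+]2[O-])CC1)Nc1ccccc1F` gives 270 nM in this assay.

Compound 3 carries the highest number of the three. Its nearest neighbour is compound 1, and the gap between them, a 1.7-fold higher number from compound 1 to compound 3 (0.23 log units; within the scatter), stays within the scatter. The gap to compound 2, a 4.1-fold higher number from compound 2 to compound 3 (0.61 log units; beyond the scatter), lies beyond it.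

Compound 4 `Cc1cccc(C)c1NC(=O)CN1CCC(c2cccc[n+]2[O-])CC1` is not yet measured. It differs from compound 3 in one place: 2,6-dimethylphenyl in place of 2-fluorophenyl on an amide-type nitrogen. All three measured steps change the same aryl group on the amide-type nitrogen, so all three bear on this change. Two of them, a 2.4-fold lower number from compound 1 to compound 2 (0.38 log units; beyond the scatter) and a 4.1-fold higher number from compound 2 to compound 3 (0.61 log units; beyond the scatter), are modest steps; the third, a 1.7-fold higher number from compound 1 to compound 3 (0.23 log units; within the scatter), is within the scatter. For the measured compounds named here, none of the measured compounds carries a 2,6-dimethylphenyl, so the step is expected to be small, with a lean toward a lower number because compound 2, which also carries a methyl group on its aryl, gives 66 nM. The expected step is a 1.8-fold lower number from compound 3 to compound 4 (0.26 log units; within the scatter). Compound 4 is therefore estimated at 150 nM, within a range from 50 nM to 450 nM.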

Compound 4, half-maximal effective concentration: 346 nM
Beside the measured number, compound 4's estimate is 2.3-fold (0.36 log units) below it; the measured number falls inside the stated range.
By their numbers in this assay, from the lowest: compound 2; then compounds 1, 3 and 4 (each within the scatter of the next, the first and the last beyond it).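

In this assay, the step of a 1.3-fold higher number from compound 3 to compound 4 (0.11 log units; within the scatter) leaves the two compounds indistinguishable, so 2,6-dimethylphenyl and 2-fluorophenyl on the amide-type nitrogen read alike here. A methyl group on the aryl ring therefore does not by itself go with the low number of compound 2: compound 4 also carries methyl groups, yet a 5.2-fold higher number from compound 2 to compound 4 (0.72 log units; beyond the scatter) is the widest gap in the set, and a 2.2-fold higher number from compound 1 to compound 4 (0.33 log units; beyond the scatter) also lies beyond the scatter. No measured evidence is available to explain these differences.

For the compounds shown here, compound 2 remains the only compound here with a bromine, and it also has a different arrangement of groups on the ring, so the source of its lower number stays open. A 4-bromophenyl group without the methyl, or a 4-methoxyphenyl group, would help separate these possibilities.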